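A few compounds are considered here, and "the series" means these few. Any claim that something is new, unique, unknown or untested is made for them only; others in the source may bear on it.

Measured compounds:
compound 1, `Cc1cc(C#N)cc(C)c1Oc1ccnc(Nc2ccc(C#N)cc2)n1`, with 1.64 in a physicochemical assay for lipophilicity; a higher number here means a more lipophilic compound, a lower number a more polar compound;
compound 2, `Cc1cc(C)c(Oc2ccnc(Nc3ccc(C#N)cc3)n2)c(C)c1`, with 2.07 in this assay;
compound 3, `Cc1cc(C#N)cc(C)c1Nc1nc(Nc2ccc(C#N)cc2)ncc1Br`, with 1.64 in this assay.

Compound 2 differs from compound 1 by methyl in place of cyano on an aromatic carbon. In this assay this change gave a number 0.43 log units higher from compound 1 to compound 2 (beyond the scatter). Compound 3 has a different core from compound 1; the difference between the two cores is not broken down here. Compound 1 and compound 3 sit level in this assay, and both lie lower than compound 2.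

Compound 4, `Cc1cc(C)c(Nc2nc(Nc3ccc(C#N)cc3)ncc2Br)c(C)c1`, is not yet measured. It differs from compound 3 by methyl in place of cyano on an aromatic carbon. The surroundings of the exchanged group in this pair read the same as in compound 1 and compound 2, so this is the same change on the second core. Among these compounds it occurs twice.

The step from compound 3 to compound 4 in this assay is estimated at a number 0.43 log units higher from compound 3 to compound 4 (beyond the scatter). This rests on compound 1 and compound 2, where the same change gave a number 0.43 log units higher from compound 1 to compound 2 (beyond the scatter). Compound 4 is therefore expected to give 2.07, within a range from 1.75 to 2.4.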

Compound 4, partition coefficient: 2.07
Beside the measured number, compound 4's estimate shows no gap at the digits printed, and the stated range covers the measured number.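

In this assay the exchange of cyano for methyl gave a number 0.43 log units higher from compound 3 to compound 4 (beyond the scatter) on the second core, and this reads the same as a number 0.43 log units higher from compound 1 to compound 2 (beyond the scatter) on the first, so in this series the step carried over from one core to the other with its size intact. This is one change on two cores in a single assay, so it shows agreement for these two pairs and does not establish a rule for other cores or for other exchanges. Nothing given here accounts for why the two steps agree.

Going by these compounds, whether the step would keep its size on a third core remains open, as does what an amine, a carboxylic acid or a longer chain would do in place of the cyano on either core. On these data alone, the difference between the core of compound 1 and the core of compound 3 also remains unbroken into its parts, so what each part contributes stays unknown.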